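From Dichlorophenyl to Methylphenyl in a Cytotoxicity Assay

The compounds below may be only part of what the source reports. "The series", "measured", "known", "first", "only" and "open" are said of these compounds alone.

Compound 1 `CCC1(Cc2ccccc2)OS(=O)(=O)C=C1OCc1ccc(OC)cc1`: > 200000 nM, a limit of the assay.
Compound 2 `CCC1(Cc2ccccc2)OS(=O)(=O)C=C1OCC1CCCCC1`: > 200000 nM, a limit of the assay.
Compound 3 `CCC1(Cc2ccccc2)OS(=O)(=O)C=C1OCc1ccc(Cl)c(Cl)c1`: 36700 nM.

In an ADME assay on HEL cells (Homo sapiens) for cytotoxicity, with a stated time of 3 days (a higher number here means that more compound is tolerated, a lower number that less compound is tolerated), compound 3 gives the only number shown; the two further values are limits. Both steps that reach compound 3 point the same way: an at least 5.4-fold lower number from compound 1 to compound 3 (0.73 log units; beyond the scatter) and an at least 5.4-fold lower number from compound 2 to compound 3 (0.73 log units; beyond the scatter). Among the compounds with values here, in each case the 3,4-dichlorophenyl compound is the one with the lower number, and the other partner sits at the limit of > 200000 nM in this assay, at which 2 of the 3 values shown sit.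

Compound 4 `CCC1(Cc2ccccc2)OS(=O)(=O)C=C1OCc1ccc(C)cc1` is not yet measured. It differs from compound 3 in one place: 4-methylphenyl in place of 3,4-dichlorophenyl on a saturated chain carbon bound to an oxygen on an unsaturated carbon. Within the data shown here, the nearest measured comparison is compound 1, whose 4-methoxyphenyl gave a limit, while 3,4-dichlorophenyl gave the one number below it. Since 4-methylphenyl is a single-substituent phenyl like 4-methoxyphenyl rather than the dichlorinated ring, the expectation is that compound 4 moves back toward the limit, a rise of about a 4.1-fold higher number from compound 3 to compound 4 (0.61 log units; beyond the scatter) in this assay. The estimate for compound 4 is 150000 nM, with a range from 40000 nM to 300000 nM, and a fair chance that only a limit is reported.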

Compound 4, half-maximal cytotoxic concentration: 41500 nM
Estimate against measurement, compound 4: 3.6-fold (0.56 log units) above, and the stated range covers the measured number.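

In this assay, 4-methylphenyl in place of 3,4-dichlorophenyl gives a 1.1-fold higher number from compound 3 to compound 4 (0.05 log units; within the scatter), so a ring without chlorine can stand on this saturated chain carbon with no readable change, and the lower number is not tied to the chlorine atoms. The smaller edit, methyl in place of methoxy on an aromatic carbon, gives an at least 4.8-fold lower number from compound 1 to compound 4 (0.68 log units; beyond the scatter), and 4-methylphenyl in place of cyclohexyl gives an at least 4.8-fold lower number from compound 2 to compound 4 (0.68 log units; beyond the scatter), which puts the line in this series between the 4-methoxyphenyl and cyclohexyl compounds on one side and the two compounds with numbers on the other. Compound 1 and compound 2 remain limits rather than numbers: the limit of > 200000 nM in this assay, at which 2 of the 4 values shown sit.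

As far as these compounds go, the true size of those two steps therefore stays unknown, as each is only a lower bound. From the compounds shown here alone, it also stays open whether the methoxy result extends to other groups on the ring, since an amine or a carboxylic acid in place of methyl on the aromatic carbon, or a longer chain in place of cyclohexyl, could fall on either side of that line.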